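A Nitrophenyl Takes the Place of the Halogenated Phenyl

The compounds below may be only part of what the source reports. "The series", "measured", "known", "first", "only" and "open" are said of these compounds alone.

Going by the values given here, compound 2 `Cn1c(=O)c(=O)n(C2CCCC2)c2nc(N/N=C/c3ccc(F)cc3Br)ncc21` gives the lowest number of the two measured so far in a functional assay on PC-3 cells (Homo sapiens) for antiproliferative activity, read by MTT assay (a higher number here means a weaker inhibitor, a lower number a stronger inhibitor), namely 9250 nM. Its nearest neighbour, compound 1 `Cn1c(=O)c(=O)n(C2CCCC2)c2nc(N/N=C/c3ccccc3)ncc21`, gives 48200 nM. Among the compounds with values here, the one measured step, a 5.2-fold lower number from compound 1 to compound 2 (0.72 log units; beyond the scatter), came from putting 2-bromo-4-fluorophenyl in place of phenyl on a carbon with a double bond to nitrogen. Compound 3 `Cn1c(=O)c(=O)n(C2CCCC2)c2nc(N/N=C/c3cccc([N+](=O)[O-])c3)ncc21` differs from compound 2 by 3-nitrophenyl in place of 2-bromo-4-fluorophenyl on a carbon with a double bond to nitrogen. Within the data shown here, no measured step tests a nitro group on this ring, so the only guide is that changing the groups on this ring moved the number modestly between compound 1 and compound 2. Compound 3 is therefore expected to land between those two, with a 2.2-fold higher number from compound 2 to compound 3 (0.33 log units; beyond the scatter) as the expected step, a somewhat higher number than compound 2. The estimate for compound 3 is 20000 nM, with a range from 6000 nM to 65000 nM.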

Compound 3, half-maximal inhibitory concentration: 20300 nM
Compound 3: the middle estimate sits 1.0-fold (0.01 log units) below what was measured; low and high end bracket the measured number.
By their numbers in this assay, from the lowest: compound 2; then compound 3; then compound 1.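

Going by these compounds alone, a single nitro group on the phenyl ring is enough to shift the result in this assay: there is a 2.4-fold lower number from compound 1 to compound 3 (0.38 log units; beyond the scatter), so the two halogens of compound 2 are not the only change on this ring that lowers the number. Yet the exchange of one substituted ring for the other gives a 2.2-fold higher number from compound 2 to compound 3 (0.34 log units; beyond the scatter), so at this position 3-nitrophenyl does not match 2-bromo-4-fluorophenyl. No measurement offered here explains why these rings differ.

With bromine and fluorine present only together in compound 2, the compounds shown leave open what either halogen does alone on this ring. They also leave open whether the nitro group would give a different number elsewhere on the ring, and what an amine or a carboxylic acid would do there.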